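Swapping methyl for tert-butoxycarbonyl on a well-tolerated amide

The compounds below may be only part of what the source reports. "The series", "measured", "known", "first", "only" and "open" are said of these compounds alone.

Compound 3 `CNC(=O)c1ccc(CN2C(=O)c3ccccc3S2(=O)=O)cc1` reaches only a limit in an ADME assay on RAW264.7 cells (Mus musculus) for cytotoxicity, read by WST assay (a higher number here means that more compound is tolerated, a lower number that less compound is tolerated), namely > 100000 nM. Compound 2 `NC(=O)c1ccc(CN2C(=O)c3ccccc3S2(=O)=O)cc1` also gives only a limit, > 100000 nM. Compound 1 `O=C(c1ccc(CN2C(=O)c3ccccc3S2(=O)=O)cc1)N1CCCCC1` gives a real number, 69200 nM. Compound 4 `CC(C)(C)OC(=O)NC(=O)c1ccc(CN2C(=O)c3ccccc3S2(=O)=O)cc1` carries tert-butoxycarbonyl in place of methyl on the amide-type nitrogen of compound 3: tert-butoxycarbonyl in place of methyl on an amide-type nitrogen. Two measured steps changed the group on the same carbonyl carbon, and neither is shown beyond the scatter: an at least 1.4-fold higher number from compound 1 to compound 2 (0.15 log units; that floor lies within the scatter), and an at least 1.4-fold higher number from compound 1 to compound 3 (0.15 log units; that floor lies within the scatter). Only a small move towards a lower number is therefore expected in this assay. The expected change is an at least 1.3-fold lower number from compound 3 to compound 4 (0.12 log units; that floor lies within the scatter). Compound 4 is estimated at 75000 nM, with an expected range from 30000 nM to 150000 nM.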

Compound 4, concentration lethal to 50% of the cells: > 100000 nM
Compound 4: a limit, no number; the forecaster's own chance of this, stated with the estimate: 40%; middle value at least 1.3-fold (0.12 log units) from the limit.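

In this assay, tert-butoxycarbonyl in place of methyl on the amide-type nitrogen still leaves compound 4 at a limit, not a number: > 100000 nM. Against the one real number in the set, the change of group on the carbonyl carbon gives an at least 1.4-fold higher number from compound 1 to compound 4 (0.15 log units; that floor lies within the scatter). The steps to compound 4 from compound 2 and from compound 3 cannot be read, because each has a limit at both ends: the limit of > 100000 nM in this assay, at which 3 of the 4 values shown sit.

Still open, as far as these compounds go, is whether an amine or a carboxylic acid carried on a longer chain at this nitrogen would give a real number in this assay.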